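Swapping the Amide Substituent: What to Expect for Compound 3

The source may report more compounds than this note shows. Statements on the series, on what has been measured and on what is new or still open speak of the compounds shown alone.

Measured so far:
- compound 1 `COc1ccc2c(=O)c(/C=C/C(=O)Nc3cc(C)ccc3C)coc2c1`: 11100 nM
- compound 2 `O=C(/C=C/c1coc2cc(O)ccc2c1=O)Nc1ccccc1`: 3880 nM

Both compounds were tested in a functional assay on Huh-7 cells (Homo sapiens) for inhibition, read by MTT assay, with a stated time of 48 h; on this read-out lower numbers stand for stronger inhibition and higher numbers for weaker inhibition. Compound 1 gives 11100 nM in this assay, and compound 2 gives 3880 nM. Compound 1 therefore stands at the higher of the two numbers, meaning weaker inhibition, and the gap to compound 2 lies beyond the usual scatter. Among the measured compounds shown here, the two compounds differ in more than one place, so no single structural step connects them.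

Compound 3 `COc1ccc2c(=O)c(/C=C/C(=O)NCc3ccc(F)cc3F)coc2c1` is not yet measured. It differs from compound 1 in one place: 2,4-difluorobenzyl in place of 2,5-dimethylphenyl on an amide-type nitrogen. For the measured compounds named here, no measured pair shows what such a change does here, so the expectation rests on compound 1 alone. The step expected is a 1.1-fold higher number from compound 1 to compound 3 (0.03 log units; within the scatter), which stays within the scatter. Compound 3 is accordingly estimated at 12000 nM, within a range from 4000 nM to 36000 nM.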

Compound 3, half-maximal inhibitory concentration: > 100000 nM
Compound 3: only a limit was reported (the forecaster's own chance of this, stated with the estimate: 15%); middle value at least 8.3-fold (0.92 log units) away from the limit.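

This step shows what compound 1 alone could not: the amide-type nitrogen is not indifferent to its substituent, since 2,4-difluorobenzyl in place of 2,5-dimethylphenyl gives an at least 9.0-fold higher number from compound 1 to compound 3 (0.95 log units; beyond the scatter) in this assay. Two groups of similar size, each with one six-membered aromatic ring, can therefore give clearly different results here. Compound 3 gives > 100000 nM, which is a limit and not a number, so the full size of the step cannot be read: the limit of > 100000 nM in this assay, at which 1 of the 3 values shown sits.

The change alters both the group's benzyl form and the substituents on its ring, and these compounds cannot separate the two. A 2,4-difluorophenyl group or a 2,5-dimethylbenzyl group on the same nitrogen would show which part of the change goes with the weaker inhibition.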